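A few compounds are considered here, and "the series" means these few. Any claim that something is new, unique, unknown or untested is made for them only; others in the source may bear on it.

In an ADME assay on J774.A1 cells (Mus musculus) for cytotoxicity, read by MTT assay, with a stated time of 72 h (a lower number here means that less compound is tolerated, a higher number that more compound is tolerated), compound 1 (`CC1(c2ccc(-c3ccco3)cc2)CC(S(=O)(=O)c2ccc(F)cc2)=C(c2ccc(/C(N)=N\O)cc2)O1`) gives 4560 nM, compound 2 (`CC1(Cc2ccccc2)CC(S(=O)(=O)c2ccc(F)cc2F)=C(c2ccc(/C(N)=N\O)cc2)O1`) gives 41500 nM, and compound 3 (`CC1(c2ccc(-c3cccc([N+](=O)[O-])c3)cc2)CC(S(=O)(=O)c2ccc(F)cc2)=C(c2ccc(/C(N)=N\O)cc2)O1`) gives 11100 nM, the second highest of the three numbers. Compound 4 (`CC1(c2ccc(Br)cc2)CC(S(=O)(=O)c2ccc(F)cc2)=C(c2ccc(/C(N)=N\O)cc2)O1`) has not yet been measured. It departs from compound 3 with bromo in place of 3-nitrophenyl on an aromatic carbon, para to a large group: bromo in place of 3-nitrophenyl on an aromatic carbon. Going by the values given here, only one measured step bears on this change, the modest 2.4-fold higher number from compound 1 to compound 3 (0.39 log units; beyond the scatter), where 3-nitrophenyl replaced furan-2-yl. That single step fixes no direction, so no step beyond the scatter is expected in this assay. For compound 4, the estimated value is 12000 nM, with an expected range from 5000 nM to 30000 nM. This estimate means an expected 1.1-fold higher number from compound 3 to compound 4 (0.03 log units; within the scatter).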

Compound 4, half-maximal cytotoxic concentration: 10500 nM
Compound 4: middle estimate off by 1.1-fold (0.06 log units), on the high side, and the stated range covers the measured number.
By their numbers in this assay, from the lowest: compound 1; then compounds 4 and 3 (each within the scatter of the next); then compound 2.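

In this assay, bromo in place of 3-nitrophenyl on this aromatic carbon, para to a large group, gives a 1.1-fold lower number from compound 3 to compound 4 (0.02 log units; within the scatter), so losing that whole six-membered aromatic ring leaves the number within the scatter. Bromo in place of furan-2-yl gives a 2.3-fold higher number from compound 1 to compound 4 (0.36 log units; beyond the scatter), so the presence of a ring here does not by itself set the number, since compound 1 and compound 3 both carry one. Nothing given here explains this. Going by these compounds, whether a small amine or a carboxylic acid on this carbon would stay with compound 3 and compound 4 or fall toward compound 1 remains open.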